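Aryl swap on the ring nitrogen: outlook for compound 3

A few compounds are considered here, and "the series" means these few. Any claim that something is new, unique, unknown or untested is made for them only; others in the source may bear on it.

In a functional assay on MCF7 cells (Homo sapiens) for inhibition, read by MTT assay, with a stated time of 72 h (on this read-out higher numbers stand for weaker inhibition and lower numbers for stronger inhibition), compound 1 `COc1ccccc1-n1c(-c2coc3cc(C)c(Cl)cc3c2=O)nc(-c2ccccc2)c1-c1ccccc1` gives 25000 nM, and compound 2 `Cc1cc2occ(-c3nc(-c4ccccc4)c(-c4ccccc4)n3-c3ccc(Br)cc3)c(=O)c2cc1Cl` gives 1560 nM. Among the measured compounds shown here, compound 2 stands at the lowest of the two numbers; the single measured step, a 16-fold lower number from compound 1 to compound 2 (1.20 log units; beyond the scatter), came with 4-bromophenyl in place of 2-methoxyphenyl on the aromatic nitrogen. Compound 3 `COc1cccc(-n2c(-c3coc4cc(C)c(Cl)cc4c3=O)nc(-c3ccccc3)c2-c2ccccc2)c1` differs from compound 2 by 3-methoxyphenyl in place of 4-bromophenyl on an aromatic nitrogen. This is in kind the reverse of the measured step, a methoxyphenyl again replacing the 4-bromophenyl, but as 3-methoxyphenyl rather than the 2-methoxyphenyl of compound 1, so that step bears on it only in part. For the measured compounds named here, a higher number is expected for compound 3, moving toward compound 1 with its 25000 nM, with the size uncertain since no measured pair shows the 3-methoxyphenyl. Compound 3 is estimated at 8000 nM, range 2500 nM to 25000 nM, an expected step of a 5.1-fold higher number from compound 2 to compound 3 (0.71 log units; beyond the scatter) in this assay.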

Compound 3, half-maximal inhibitory concentration: 25000 nM
Beside the measured number, compound 3's estimate is 3.1-fold (0.49 log units) below it, and the stated range covers the measured number.
By their numbers in this assay, from the lowest: compound 2; then compounds 1 and 3 (each within the scatter of the next).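

The change from 4-bromophenyl to 3-methoxyphenyl on the aromatic nitrogen gives a 16-fold higher number from compound 2 to compound 3 (1.20 log units; beyond the scatter), so the lower number of compound 2 is not tied to the 2-methoxyphenyl of compound 1 alone. Moving the methoxy group from the 2-methoxyphenyl to the 3-methoxyphenyl arrangement gives no change at the digits printed from compound 1 to compound 3 (within the scatter) and thus separates neither methoxyphenyl from the other at this position. Nothing available gives a reason for the gap between the 4-bromophenyl and the two methoxyphenyl groups.

The compounds shown do not separate the bromine from its place on the phenyl ring, which a 4-methoxyphenyl or a 3-bromophenyl would do. As far as these compounds go, how an aminophenyl, a carboxyphenyl or a benzyl group on this nitrogen would read also remains open.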